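A Hydroxyl Joins the Methoxy on One Arylidene Arm

The source may hold more compounds than are shown below. What is called first, only, known or untested is meant among the compounds shown, and "the series" means these compounds.

Among the compounds with values here, compound 1 `COc1ccc(/C=C2\CCC/C(=C\c3ccc(OC)c(OC)c3)C2=O)cc1` is one of two compounds measured in a functional assay on HT-1080 cells (Homo sapiens) for cytotoxicity, read by MTT assay, with a stated time of 72 h; on this read-out lower numbers stand for stronger inhibition and higher numbers for weaker inhibition. In this assay compound 1 gives 7200 nM, the lower of the two numbers, while compound 2 `COc1ccc(/C=C2\CCC/C(=C\c3ccc(OC)c(OC)c3)C2=O)c(OC)c1` gives 17100 nM. Within the data shown here, the only step measured so far, a 2.4-fold higher number from compound 1 to compound 2 (0.38 log units; beyond the scatter), involves methoxy in place of hydrogen on an aromatic carbon and runs toward a higher number. Compound 3 `COc1cc(/C=C2\CCC/C(=C\c3ccc(OC)c(OC)c3)C2=O)ccc1O` differs from compound 1 by 4-hydroxy-3-methoxyphenyl in place of 4-methoxyphenyl on a double-bonded chain carbon bound to a double-bonded ring carbon. This change keeps the methoxy of compound 1 and adds a hydroxyl rather than a methoxy, so the measured step is only a loose guide; it bears on the change in that both add an oxygen substituent to the same arylidene arm, but with a different group. He therefore expects a 1.2-fold lower number from compound 1 to compound 3 (0.08 log units; within the scatter), a small step within or close to the scatter. His estimate for compound 3 in this assay is 6000 nM, with a range from 2500 nM to 15000 nM.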

Compound 3, half-maximal inhibitory concentration: 4600 nM
The estimate for compound 3 lay 1.3-fold (0.12 log units) above the measured number; low and high end bracket the measured number.
By their numbers in this assay, from the lowest: compounds 3 and 1 (each within the scatter of the next); then compound 2.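

In this assay, a 1.6-fold lower number from compound 1 to compound 3 (0.19 log units; within the scatter) shows that this arm can take 4-hydroxy-3-methoxyphenyl in place of 4-methoxyphenyl without the number leaving the scatter. The earlier step, a 2.4-fold higher number from compound 1 to compound 2 (0.38 log units; beyond the scatter), had gone beyond the scatter, so the compounds shown now hold one added oxygen substituent on this arm that raises the number beyond the scatter and one that does not. No evidence is at hand to explain the difference between these two changes.

From the compounds shown here alone, the step from compound 1 to compound 3 brings the hydroxyl and the shifted methoxy together, so the share of each in the result remains open. Also open, going by these compounds, is how this arm would behave with a group of another kind, such as an amine or a carboxylic acid, in place of the hydroxyl.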